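Adding One Methoxy Group to Compound 1

The compounds below may be only part of what the source reports. "The series", "measured", "known", "first", "only" and "open" are said of these compounds alone.

Compound 1 `COc1ccc(-c2cc(C(=O)/C=C/c3ccccc3)nc3cc(-c4ccccc4)nn23)cc1OC` and compound 2 `COc1ccc(C(=O)/C=C/c2cc(-c3cc(OC)c(OC)c(OC)c3)n3nc(-c4ccccc4)cc3n2)cc1` were both tested in a functional assay on DU-145 cells (Homo sapiens) for antiproliferative activity, read by MTT assay, with a stated time of 24 h; on this read-out higher numbers stand for weaker inhibition and lower numbers for stronger inhibition. In this assay compound 1 gives 15600 nM, and compound 2 gives 25200 nM; these two numbers sit within the scatter of each other, so neither stands apart. Compound 3 `COc1ccc(/C=C/C(=O)c2cc(-c3ccc(OC)c(OC)c3)n3nc(-c4ccccc4)cc3n2)cc1` differs from compound 1 by methoxy in place of hydrogen on an aromatic carbon. Within the data shown here, no measured pair shows this change, so only a small step is expected, if any, leaning slightly toward stronger inhibition. Compound 3 is estimated at 12000 nM, within a range from 5000 nM to 30000 nM, which means an expected step of a 1.3-fold lower number from compound 1 to compound 3 (0.11 log units; within the scatter).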

Compound 3, half-maximal inhibitory concentration: 14900 nM
Compound 3: the middle estimate sits 1.2-fold (0.09 log units) below what was measured, and the stated range covers the measured number.
By their numbers in this assay, from the lowest: compounds 3, 1 and 2 (each within the scatter of the next).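

In this assay, methoxy in place of hydrogen, which turns 2-phenylethenyl into 2-(4-methoxyphenyl)ethenyl, gives a 1.0-fold lower number from compound 1 to compound 3 (0.02 log units; within the scatter). Among these compounds, this is the first measured step for this change, and it shows that this position, para to a large group, takes the added methoxy with no readable shift in the number. No supporting measurement here explains this result. On these data alone, whether an amine or a carboxylic acid at this position would shift the number remains open. So does whether methoxy added elsewhere on the core of compound 1 would behave the same way.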